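Chloro in Place of Hexylamino on the Shared Core

This account rests on a few compounds, and the source may have more. Where it says the series, first, only, none or still open, it means among the compounds named here.

Compound 3 `CCCCCCNc1nccc2c1ncn2C1O[C@H](CO)[C@@H](O)[C@H]1O` is the only one of the three measured compounds to return a number in a functional assay on EL4 cells (Mus musculus) for inhibition, tested at 100 uM (a lower number here means less inhibition, a higher number more inhibition at the concentration tested (going by the name of the read-out)), where compound 3 gives 14%. Compound 1 `CSc1nccc2c1ncn2C1O[C@H](CO)[C@@H](O)[C@H]1O` sits at a limit of the assay, giving < 5% in this assay. Compound 2 `OC[C@H]1OC(n2cnc3c(S)nccc32)[C@H](O)[C@@H]1O` also sits at a limit, giving < 5% in this assay. Both limits come from the limit of < 5% in this assay, at which 2 of the 3 values shown sit. The step from compound 1 to compound 3 shows a number at least 9 percentage points higher from compound 1 to compound 3 (that floor lies within the scatter), and the step from compound 2 to compound 3 shows a number at least 9 percentage points higher from compound 2 to compound 3 (that floor lies within the scatter); in each the hexylamino group enters on an aromatic carbon and the number rises.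

Compound 4 `OC[C@H]1OC(n2cnc3c(Cl)nccc32)[C@H](O)[C@@H]1O` differs from compound 3 by chloro in place of hexylamino on an aromatic carbon. This runs the opposite way to the two measured steps, in which hexylamino entered and the reading went up. The step from compound 3 to compound 4 is therefore expected to be a number 11 percentage points lower from compound 3 to compound 4 (beyond the scatter), a fall back toward the limit. The estimate for compound 4 in this assay is 3%, expected to lie between 0% and 10%.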

Compound 4, a percentage reported as inhibition, at one concentration (the size of the read-out at that concentration, not a potency): < 5%
Compound 4 was reported as a limit; the forecaster's own chance of this, stated with the estimate: 70%; the middle value lies beyond the limit too.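

Among the compounds shown here, the change from hexylamino to chloro on this aromatic carbon gives a number at least 9 percentage points lower from compound 3 to compound 4 (that floor lies within the scatter) in this assay, so among the four compounds only the one carrying hexylamino gives a number rather than a limit. Chloro now joins methylsulfanyl and sulfanyl, so three different groups at this place, next to the ring nitrogen, end at the same limit: the limit of < 5% in this assay, at which 3 of the 4 values shown sit. The steps from compound 1 and from compound 2 to compound 4 cannot be read, as both ends of each are limits.

From the compounds shown here alone, it remains open whether a plain amine, a butylamino group or a longer chain such as octylamino at this place would give a number above the limit. The shared limit also leaves the order among chloro, sulfanyl and methylsulfanyl undecided.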